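The compounds below may be only part of what the source reports. "The series", "measured", "known", "first", "only" and "open" are said of these compounds alone.

Three compounds of the series have a number in an assay on SK-BR-3 cells for inhibition of Aromatase (Homo sapiens) (a higher number here means a weaker inhibitor, a lower number a stronger inhibitor), so far. Compound 1 `CS(=O)(=O)Nc1ccc([N+](=O)[O-])cc1OCc1ccc(F)cc1` gives 580 nM. Going by the values given here, compound 2 `CS(=O)(=O)Nc1ccc([N+](=O)[O-])cc1OCc1ccc(Br)cc1` gives 5850 nM, and the one counted step in the set, a 10-fold higher number from compound 1 to compound 2 (1.00 log units; beyond the scatter), lies beyond the scatter. Compound 3 `CN(c1ccc(N)cc1OCc1ccccc1)S(C)(=O)=O` gives 1100 nM; it stands second highest of the three numbers, nearest to compound 1 and within the scatter of it, furthest from compound 2 and beyond the scatter of that one.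

Compound 4 `CN(c1ccc(NC(=O)c2ccccc2)cc1OCc1ccccc1)S(C)(=O)=O` has not yet been measured in this assay. It differs from compound 3 by benzoyl in place of hydrogen on a nitrogen on an aromatic ring. Among the compounds with values here, no measured step bears on this change: the only counted step, from compound 1 to compound 2, exchanges one halogen for another on an aromatic carbon of the shared core, not a substituent on the aromatic nitrogen, and the series holds no other acylation of that nitrogen. On these data alone, the size and direction of the step in this assay therefore cannot be read from the data; a result within the scatter or a modest shift either way is equally open. Compound 4 is expected to give about 1500 nM in this assay, within a range from 350 nM to 6500 nM. The estimated step of a 1.4-fold higher number from compound 3 to compound 4 (0.13 log units; within the scatter) is accordingly small, with wide uncertainty.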

Compound 4, half-maximal inhibitory concentration: 1770 nM
Compound 4: middle estimate off by 1.2-fold (0.07 log units), on the low side; the measured number falls inside the stated range.
By their numbers in this assay, from the lowest: compounds 1, 3 and 4 (each within the scatter of the next, the first and the last beyond it); then compound 2.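

In this assay, benzoyl in place of hydrogen on a nitrogen on an aromatic ring gives a 1.6-fold higher number from compound 3 to compound 4 (0.21 log units; within the scatter), so the change from amino to benzamido stays within the scatter. Going by these compounds alone, this is the first reading at this position: a group of 8 heavy atoms, with a six-membered aromatic ring and a carbonyl, enters on this nitrogen without a step beyond the scatter, whereas the halogen exchange, a 10-fold higher number from compound 1 to compound 2 (1.00 log units; beyond the scatter), lies beyond it at a different place on the series. No measurement in hand offers an explanation for the result at this nitrogen.

This single step does not settle how far the position accepts change in general: an acetyl group, a longer chain such as phenylacetyl, or a sulfonamide on the same nitrogen could each fall within the scatter of compound 3 or beyond it. Also open, on these data alone, is whether fluoro, bromo or a carboxylic acid on the benzoyl ring would shift the number, and whether the halogen step seen between compound 1 and compound 2 would carry over to that ring.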